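The source may hold more compounds than are shown below. What is called first, only, known or untested is meant among the compounds shown, and "the series" means these compounds.

Compound 1 `Cn1c(-c2ccccc2)nc2c(Sc3ccccc3)ncnc21`: 1%
Compound 2 `CSc1ccc(-c2nc3c(Sc4ccccc4)ncnc3n2C)cc1`: 0%

In an assay on isolated protein for inhibition of Rho-associated protein kinase 1 (Homo sapiens), tested at 30 uM (on this read-out lower numbers stand for less inhibition and higher numbers for more inhibition at the one concentration tested (going by the name of the read-out)), compound 1 gives 1%, and in the same assay compound 2 gives 0%. Compound 2 has the lower of the two numbers, its nearest neighbour being compound 1, and the step of a number 1 percentage points lower from compound 1 to compound 2 (within the scatter) lies within the scatter, so the two compounds cannot be ranked on this read-out.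

Compound 3 `Cn1c(-c2ccc([S+](C)[O-])cc2)nc2c(Sc3ccccc3)ncnc21` differs from compound 2 in one place: a group of 3 heavy atoms (1 carbon, 1 oxygen, 1 sulfur; no ring) in place of a group of 2 heavy atoms (1 carbon, 1 sulfur; no ring), on an aromatic carbon. Among the measured compounds shown here, the only measured step touching this position is the one from compound 1 to compound 2, which introduced the methylsulfanyl that now leaves, and it produced no change beyond the scatter. Nothing measured here suggests that the entering group will behave differently. The step of a number 2 percentage points higher from compound 2 to compound 3 (within the scatter) is therefore expected to stay within the scatter. Compound 3 is estimated to give 2% in this assay, with a range from 0% to 15%.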

Compound 3, a percentage reported as inhibition, at one concentration (the size of the read-out at that concentration, not a potency): 1%
Beside the measured number, compound 3's estimate is 1 percentage points above it; low and high end bracket the measured number.
By their numbers in this assay, from the lowest: compounds 2, 1 and 3 (each within the scatter of the next).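

Replacing methylsulfanyl with the group of 3 heavy atoms gives a number 1 percentage points higher from compound 2 to compound 3 (within the scatter) in this assay, and the same group in place of hydrogen gives no change at the digits printed from compound 1 to compound 3 (within the scatter) on the same read-out. This aromatic carbon has now carried three different occupants without any separation beyond the scatter, so the flat result is not confined to methylsulfanyl. No available measurement explains this flat result.

Going by these compounds, whether an amine, a carboxylic acid or a longer chain on this carbon would move the number beyond the scatter remains open. Among the compounds shown here, also open is whether any change elsewhere on the shared core would do so, since these compounds offer no example of substantial inhibition at the one concentration tested.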